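A few compounds are considered here, and "the series" means these few. Any claim that something is new, unique, unknown or untested is made for them only; others in the source may bear on it.

Measured compounds:

compound 1, `Cc1ccccc1OS(=O)(=O)c1ccc(N2CCN(C)C2=O)cc1`, 4800 nM
compound 2, `COc1ccccc1OS(=O)(=O)c1ccc(N2CCN(C)C2=O)cc1`, 26000 nM
compound 3, `CCCN1CCN(c2ccc(S(=O)(=O)Oc3ccc(C)cc3)cc2)C1=O`, 25000 nM

Of the compounds shown here, three have been tested in a functional assay on HT-29 cells (Homo sapiens) for antiproliferative activity, read by sulforhodamine B assay, with a stated time of 48 h; a higher number here means a weaker inhibitor, a lower number a stronger inhibitor. Compound 1, `Cc1ccccc1OS(=O)(=O)c1ccc(N2CCN(C)C2=O)cc1`, gives 4800 nM in this assay. Compound 2, `COc1ccccc1OS(=O)(=O)c1ccc(N2CCN(C)C2=O)cc1`, differs from compound 1 only in one place: methoxy in place of methyl on an aromatic carbon. That single change produced a 5.4-fold higher number from compound 1 to compound 2 (0.73 log units; beyond the scatter). Compound 3, `CCCN1CCN(c2ccc(S(=O)(=O)Oc3ccc(C)cc3)cc2)C1=O`, gives 25000 nM in this assay; its value and that of compound 2 lie within the usual scatter of each other, so nothing separates them. How the core of compound 3 differs from the core of compound 1 is not broken down here.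

Compound 4, `CCCN1CCN(c2ccc(S(=O)(=O)Oc3ccc(OC)cc3)cc2)C1=O`, has not yet been measured. It differs from compound 3 by methoxy in place of methyl on an aromatic carbon. Among the compounds with values here, this is the same kind of change as the one from compound 1 to compound 2, but not the same: in compound 2 the methoxy sits ortho to a large group, while in compound 4 it sits para to a large group. Within the data shown here, only one earlier instance of the change exists, and it was made on a different core at a different place, so the expectation for compound 4 rests on a single measured step. Because a 5.4-fold higher number from compound 1 to compound 2 (0.73 log units; beyond the scatter) was a modest weakening, compound 4 is expected to show a step of about a 2.0-fold higher number from compound 3 to compound 4 (0.30 log units; within the scatter) relative to compound 3, though the different place leaves this uncertain. The estimate for compound 4 in this assay is 50000 nM, with a range from 20000 nM to 150000 nM; a value this high might also be reported only as a limit.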

Compound 4, half-maximal inhibitory concentration: 16000 nM
The estimate for compound 4 lay 3.1-fold (0.49 log units) above the measured number; measured number below the stated range.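

In this assay, putting methoxy in place of methyl gave a 1.6-fold lower number from compound 3 to compound 4 (0.19 log units; within the scatter), a step that stays within the scatter, so on this core the change shows no measurable effect. Set beside the earlier instance, the two steps clearly disagree, and the change did not carry over from one core to the other with the same size: the same change on two cores in this assay, a 5.4-fold higher number (0.73 log units; beyond the scatter) from compound 1 to compound 2 and a 1.6-fold lower number (0.19 log units; within the scatter) from compound 3 to compound 4, 8.5-fold (0.93 log units) apart, beyond the scatter of two such steps. Within the data shown here, this rests on only two pairs, which differ both in the core and in where the change sits, with the methoxy of compound 4 para to a large group, so the data cannot show whether the core, the place or both lie behind the gap, nor how the change would behave on any further core.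

The compounds shown leave open whether the same swap, made at the place it occupies in compound 2 on the core of compound 3 and at the place it occupies in compound 4 on the core of compound 1, would separate these two factors. They also leave open how the series would respond to an amine or a carboxylic acid on the aromatic ring, or to a longer chain in place of the propyl group.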